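Chlorophenyl placement on the carbonyl in compound 3's series

The source may hold more compounds than are shown below. What is called first, only, known or untested is meant among the compounds shown, and "the series" means these compounds.

Compound 3 `O=C(Nc1ccc(Cl)c(-c2nnc3c(Cl)cccn23)c1)c1ccccc1Cl` carries a 2-chlorophenyl on the carbonyl carbon; in a functional assay on MCF7 cells (Homo sapiens) for antiproliferative activity, read by MTT assay, with a stated time of 72 h (on this read-out higher numbers stand for weaker inhibition and lower numbers for stronger inhibition), compound 3 gives 92200 nM, the highest of the two numbers obtained so far. Compound 1 `O=C(Nc1ccc(Cl)c(-c2nnc3c(Cl)cccn23)c1)c1cccc(Cl)c1`, with a 3-chlorophenyl in that place, gives 71900 nM, and the step of a 1.3-fold higher number from compound 1 to compound 3 (0.11 log units; within the scatter) stays within the scatter. Compound 2 `O=C(Nc1ccc(Cl)c(-c2nnc3c(Cl)cccn23)c1)c1c(F)cccc1Cl`, with a 2-chloro-6-fluorophenyl, returns only a limit of this assay, > 100000 nM. The step of an at least 1.3-fold higher number from compound 1 to compound 2 (0.14 log units; that floor lies within the scatter) reaches only to the floor set by the limit of > 100000 nM in this assay, at which 1 of the 3 values shown sits. The step of an at least 1.0-fold lower number from compound 2 to compound 3 (0.03 log units; that floor lies within the scatter) likewise rests on that limit.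

Compound 4 `O=C(Nc1ccc(Cl)c(-c2nnc3c(Cl)cccn23)c1)c1ccc(Cl)cc1` has not been measured; the change from compound 3 is 4-chlorophenyl in place of 2-chlorophenyl on a carbonyl carbon. Among the measured compounds shown here, of the measured steps, only the one from compound 1 to compound 3 moves chlorine to another place on the same ring, and it lies within the scatter. For the measured compounds named here, no measured compound carries a 4-chlorophenyl. The expected step for compound 4 is therefore a 1.2-fold lower number from compound 3 to compound 4 (0.06 log units; within the scatter), nothing beyond the scatter. Compound 4 is estimated at 80000 nM, between 35000 nM and 200000 nM.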

Compound 4, half-maximal inhibitory concentration: 58400 nM
For compound 4 the middle estimate is 1.4-fold (0.14 log units) above the measured one, within the range that was stated.
By their numbers in this assay, from the lowest: compounds 4, 1 and 3 (each within the scatter of the next). At a limit, above all of these: compound 2.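

With the 4-chlorophenyl in hand, three placements of the single chlorine can be compared in this assay, and none of the steps among them leaves the scatter: a 1.6-fold lower number from compound 3 to compound 4 (0.20 log units; within the scatter), and a 1.2-fold lower number from compound 1 to compound 4 (0.09 log units; within the scatter). At this position, then, compounds 1, 3 and 4 give no order among the 2-chlorophenyl, 3-chlorophenyl and 4-chlorophenyl groups. The step of an at least 1.7-fold lower number from compound 2 to compound 4 (0.23 log units; that floor lies within the scatter) is only a floor, set by a limit of the assay and not by a number: the limit of > 100000 nM in this assay, at which 1 of the 4 values shown sits.

Going by these compounds, it remains open whether replacing the chlorine on this ring with an amine or a carboxylic acid, or replacing the ring itself with a longer chain, would move the number beyond the scatter. On these data alone, whether a change in the shared core would do so also remains open.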